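The source may hold more compounds than are shown below. What is called first, only, known or untested is meant among the compounds shown, and "the series" means these compounds.

In a functional assay on M21 cells (Homo sapiens) for antiproliferative activity, read by sulforhodamine B assay, with a stated time of 48 h (on this read-out higher numbers stand for weaker inhibition and lower numbers for stronger inhibition), compound 3 `CCCC(=O)Nc1ccc(S(=O)(=O)Oc2ccccc2C(C)C)cc1` gives 6100 nM, the lowest of the three numbers shown. Its nearest neighbour is compound 2 `CCC(=O)Nc1ccc(S(=O)(=O)Oc2ccccc2C(C)C)cc1`, which gives 11000 nM and lies within the scatter of compound 3. Compound 1 `CC(=O)Nc1ccc(S(=O)(=O)Oc2ccccc2C(C)C)cc1` gives 21000 nM, and the step of a 3.4-fold lower number from compound 1 to compound 3 (0.54 log units; beyond the scatter) is the only one here that reaches beyond the scatter. Compound 4 `CC(C)C(=O)Nc1ccc(S(=O)(=O)Oc2ccccc2C(C)C)cc1` has not yet been measured in this assay. It differs from compound 3 by isopropyl in place of propyl on a carbonyl carbon: the same atoms are present, joined differently, so the group on the carbonyl carbon is branched rather than a straight chain. Among the measured compounds shown here, none of the measured steps tests such a rearrangement. The nearest comparisons are a 1.9-fold lower number from compound 1 to compound 2 (0.28 log units; within the scatter) and a 1.8-fold lower number from compound 2 to compound 3 (0.26 log units; within the scatter), each a small gain as the chain grows by a methyl, and neither is large. Since compound 4 neither lengthens nor shortens the chain of compound 3, these steps give no ground to expect a change beyond the scatter in either direction. Compound 4 is therefore estimated to give about 7000 nM in this assay, with a plausible range from 3000 nM to 16000 nM. That estimate amounts to an expected step of a 1.1-fold higher number from compound 3 to compound 4 (0.06 log units; within the scatter), essentially no change.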

Compound 4, half-maximal inhibitory concentration: 11000 nM
The estimate for compound 4 lay 1.6-fold (0.20 log units) below the measured number, within the range that was stated.
By their numbers in this assay, from the lowest: compounds 3, 2, 4 and 1 (each within the scatter of the next, the first and the last beyond it).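

Read in this assay, the change from a straight to a branched group on this carbonyl carbon gives a 1.8-fold higher number from compound 3 to compound 4 (0.26 log units; within the scatter), so swapping propyl for isopropyl at this position has no effect that can be told apart from the scatter. Among the compounds shown here, the other two new comparisons give no change at the digits printed from compound 2 to compound 4 (within the scatter) and a 1.9-fold lower number from compound 1 to compound 4 (0.28 log units; within the scatter), so isopropyl stays within the scatter of both compound 2 and compound 1, whereas propyl gives a 3.4-fold lower number from compound 1 to compound 3 (0.54 log units; beyond the scatter), the only step here beyond the scatter, although the two groups themselves cannot be separated. No measurement here explains these numbers, so no reason can be given for them.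

The four compounds leave open whether a longer straight chain such as butyl or pentyl would continue the trend seen from compound 1 to compound 3, and whether more branching, as in tert-butyl, or a closed ring, as in cyclopropyl, would move the number beyond the scatter. They also leave open whether a group of a different kind on this carbonyl carbon, such as an amine or a carboxylic acid on the chain, would be tolerated.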